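Swapping 1H-1,2,4-triazol-1-yl for 1,3-thiazol-2-yl in compound 3

The source may report more compounds than this note shows. Statements on the series, on what has been measured and on what is new or still open speak of the compounds shown alone.

In a functional assay (trachea) with Cavia porcellus as the target (a higher number here means a weaker inhibitor, a lower number a stronger inhibitor), compound 1 (`O=c1c2ccccc2c(-c2cccnc2)nn1CC1CCCCC1`) gives 209 nM. Compound 2 (`Oc1nnc(-n2ccnc2)c2ccccc12`) gives 8320 nM and compound 3 (`Oc1nnc(-n2cncn2)c2ccccc12`) gives 16600 nM, two numbers within the scatter of each other and both well above that of compound 1. Compound 4 (`Oc1nnc(-c2nccs2)c2ccccc12`) carries 1,3-thiazol-2-yl in place of 1H-1,2,4-triazol-1-yl on an aromatic carbon. Within the data shown here, the one measured step at this place is a 2.0-fold higher number from compound 2 to compound 3 (0.30 log units; within the scatter), which stays within the scatter. Among the measured compounds shown here, compound 1 differs from the others in more than one place and offers no such step. For the measured compounds named here, no measured compound carries 1,3-thiazol-2-yl, so this guide is thin, and no step beyond the scatter is expected in this assay, in either direction. The estimated step is a 1.7-fold lower number from compound 3 to compound 4 (0.22 log units; within the scatter). For compound 4 the expected value is 10000 nM, with a range from 3000 nM to 30000 nM.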

Compound 4, half-maximal inhibitory concentration: 4570 nM
For compound 4 the middle estimate is 2.2-fold (0.34 log units) above the measured one, within the range that was stated.
By their numbers in this assay, from the lowest: compound 1; then compounds 4, 2 and 3 (each within the scatter of the next, the first and the last beyond it).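

In this assay, this position now shows a change beyond the scatter, with a 3.6-fold lower number from compound 3 to compound 4 (0.56 log units; beyond the scatter) when 1,3-thiazol-2-yl replaces 1H-1,2,4-triazol-1-yl on the aromatic carbon. Set against 1H-imidazol-1-yl, the same group gives a 1.8-fold lower number from compound 2 to compound 4 (0.26 log units; within the scatter) and so stays within the scatter, which makes the gain modest and specific to the triazole comparison. No evidence is available to explain this difference between the groups. As far as these compounds go, how an amine or a carboxylic acid would behave at this place remains open.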